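Adding Two Fluorines to a Cyclohexyl Amide

A few compounds are considered here, and "the series" means these few. Any claim that something is new, unique, unknown or untested is made for them only; others in the source may bear on it.

Compound 1 `O=C(C1CCC1)N1CCc2nc(C#Cc3ccccc3)sc2C1` gives 370 nM in an assay on HEK293 cells for negative allosteric modulation of metabotropic glutamate receptor 5 (Homo sapiens), read by FLIPR, with a stated time of 1 h; a higher number here means a weaker inhibitor, a lower number a stronger inhibitor. Compound 2 `O=C(C1CCCCC1)N1CCc2nc(C#Cc3ccccc3)sc2C1` reaches only the limit of this assay, > 10000 nM. For the measured compounds named here, the single measured step, an at least 27-fold higher number from compound 1 to compound 2 (1.43 log units; beyond the scatter), thus ends at the limit of > 10000 nM in this assay, at which 1 of the 2 values shown sits. Compound 3 `O=C(C1CCC(F)(F)CC1)N1CCc2nc(C#Cc3ccccc3)sc2C1` differs from compound 2 by 4,4-difluorocyclohexyl in place of cyclohexyl on a carbonyl carbon. Going by the values given here, no measured step shows what the two fluorines do, and compound 2 already sits at the limit of > 10000 nM in this assay, at which 1 of the 2 values shown sits, so for compound 3 the expected step is a number no higher from compound 2 to compound 3 (the limit leaves the size open), within the scatter. Compound 3 is estimated at 10000 nM, most likely between 3000 nM and 30000 nM.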

Compound 3, half-maximal inhibitory concentration: > 10000 nM
Compound 3 ended at the assay's limit; the forecaster's own chance of this, stated with the estimate: 60%; the middle value lies on the limit itself.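

With two fluorines added to the cyclohexyl ring, the amide still gives no readable value: the limit of > 10000 nM in this assay, at which 2 of the 3 values shown sit. The step between compound 2 and compound 3 cannot be read, as both ends are limits, so any effect of the fluorines stays hidden. Replacing cyclobutyl with 4,4-difluorocyclohexyl gives an at least 27-fold higher number from compound 1 to compound 3 (1.43 log units; beyond the scatter), so the loss seen with plain cyclohexyl remains.

From the compounds shown here alone, whether cyclopentyl on the same carbonyl carbon would give a readable value stays open. So does whether an amine on the cyclohexyl ring would bring one back.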